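Moving from a branched amine to a secondary amine

A few compounds are considered here, and "the series" means these few. Any claim that something is new, unique, unknown or untested is made for them only; others in the source may bear on it.

Measured so far:
- compound 1, `CCCN(CC1CC1)c1nc(CC)c(-c2ccc(Cl)cc2Cl)nc1CC`, 0.2 h
- compound 2, `CCc1nc(-c2ccc(OC)nc2OC)c(CC)nc1NC(CC)CC`, 0.15 h
- compound 3, `CCc1nc(N(CC2CC2)CC2CC2)c(CC)nc1-c1ccc(Cl)cc1Cl`, 0.133 h

Going by the values given here, in an in vitro ADME assay on microsomes (Homo sapiens) for metabolic stability (a lower number here means that the compound disappears faster, a higher number that the compound lasts longer), compound 3 gives the lowest of the three numbers, but all three sit close together: its gap to compound 2 and its gap to compound 1 are both within the scatter, so no compound can be called more stable than another.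

Compound 4, `CCc1nc(-c2ccc(Cl)cc2Cl)c(CC)nc1NC(C1CC1)C1CC1`, differs from compound 3 in one place: (dicyclopropylmethyl)amino in place of bis(cyclopropylmethyl)amino on an aromatic carbon. Among the compounds with values here, the only step with numbers so far, a 1.5-fold lower number from compound 1 to compound 3 (0.18 log units; within the scatter), swaps ethyl for cyclopropyl on a chain carbon bound to the ring nitrogen and stays within the scatter; it does not involve a hydrogen-bond donor and so bears only loosely on this change. Compound 2, which also carries a secondary amino group, gives a number close to that of compound 3. On this basis compound 4 is expected to show no step beyond the scatter, a 1.1-fold higher number from compound 3 to compound 4 (0.05 log units; within the scatter). The estimate for compound 4 in this assay is therefore 0.15 h, with a range from 0.07 h to 0.32 h.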

Compound 4, half-life: 0.183 h
Beside the measured number, compound 4's estimate is 1.2-fold (0.09 log units) below it, and the stated range covers the measured number.
By their numbers in this assay, from the lowest: compounds 3, 2, 4 and 1 (each within the scatter of the next).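

Putting (dicyclopropylmethyl)amino in place of bis(cyclopropylmethyl)amino on this aromatic carbon, next to the ring nitrogen, gives a 1.4-fold higher number from compound 3 to compound 4 (0.14 log units; within the scatter) in this assay and adds an amine hydrogen, the hydrogen-bond donor that compound 3 lacks. The same group in place of (cyclopropylmethyl)(propyl)amino gives a 1.1-fold lower number from compound 1 to compound 4 (0.04 log units; within the scatter), so against both tertiary amines, the secondary amine of compound 4 brings no difference that can be read in this assay at this position. Nothing available here explains these numbers.

All the amines shown at this carbon carry only carbon groups on their nitrogen, so it remains open whether a morpholine or a chain ending in a hydroxyl group would give a step beyond the scatter. Also open, on these data alone, is how the number responds to a change elsewhere, such as replacing the 2,4-dichlorophenyl group with a pyridine alone.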